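Extending compound 3 at its aromatic oxygen

The source may hold more compounds than are shown below. What is called first, only, known or untested is meant among the compounds shown, and "the series" means these compounds.

Of the compounds shown here, three of a shared core have been measured in a functional assay (trachea) with Rattus norvegicus as the target; a higher number here means a more potent compound, by a factor of ten per unit of this negative logarithm, a lower number a less potent compound. Compound 1 `CCC(=O)c1ccc2c(c1)C(n1ccccc1=O)=CC(C)(C)O2` gives 5.85. Compound 2 `CC1(C)C=C(n2ccccc2=O)c2cc(C(=O)c3ccccc3)ccc2O1` gives 6.21. Compound 3 `CC1(C)C=C(n2ccccc2=O)c2cc(O)ccc2O1` gives 5.31, the lowest of the three numbers, with a number 0.54 log units lower from compound 1 to compound 3 (beyond the scatter) and a number 0.90 log units lower from compound 2 to compound 3 (beyond the scatter) both beyond the scatter. Compound 4 `CC1(C)C=C(n2ccccc2=O)c2cc(OCC(=O)c3ccc(F)cc3)ccc2O1` is not yet measured. It differs from compound 3 by ((4-fluorophenyl)carbonyl)methyl in place of hydrogen on an oxygen on an aromatic ring.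

Within the data shown here, the steps that bear on this change are the two leading into compound 3: a number 0.90 log units lower from compound 2 to compound 3 (beyond the scatter) and a number 0.54 log units lower from compound 1 to compound 3 (beyond the scatter). In both, a group bearing a carbonyl and a benzoyl or propanoyl chain gave way to a bare hydroxy, and the number fell. In compound 4 a ((4-fluorophenyl)carbonyl)methyl group, which also carries a carbonyl and an aromatic ring, is added on that same oxygen rather than in place of it, so the comparison is indirect. A moderate rise is therefore expected for compound 4, estimated as a number 0.69 log units higher from compound 3 to compound 4 (beyond the scatter) in this assay, giving an estimated value of 6 with a range from 5.4 to 6.6.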

Compound 4, logarithm of the reciprocal of the active concentration, log(1/C): 4.77
Estimate against measurement, compound 4: 1.23 log units above, and the stated range ends above it.
By their numbers in this assay, from the lowest: compound 4; then compound 3; then compound 1; then compound 2.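

In this assay, adding ((4-fluorophenyl)carbonyl)methyl in place of hydrogen on the aromatic oxygen gives a number 0.54 log units lower from compound 3 to compound 4 (beyond the scatter), so the hydroxy of compound 3 does not mark the low end of what this position allows. A carbonyl and an aromatic ring in the new group do not by themselves lift the number here, as compound 4 gives a lower number than compound 1 and compound 2, which also carry a carbonyl. Nothing available explains this fall.

The compounds shown do not separate the fluorine, the carbonyl and the aromatic ring, so it remains open which part of the group, if any single one, goes with the lower number. Also open, going by these compounds, is how a methyl ether, a longer chain, an amine or a carboxylic acid on this oxygen would read in this assay.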